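The source may report more compounds than this note shows. Statements on the series, on what has been measured and on what is new or still open speak of the compounds shown alone.

Values in an assay on brain for displacement of a labelled ligand from Neuronal acetylcholine receptor; alpha4/beta2 (Rattus norvegicus); on this read-out higher numbers stand for weaker inhibition and lower numbers for stronger inhibition:
compound 1 `CN(C)C1(COc2cccnc2)CC1` gives 95 nM
compound 2 `CN(C)C1(COc2cncc(Br)c2)CC1` gives 273 nM

For the measured compounds named here, compound 2 stands at the higher of the two numbers measured so far; its nearest neighbour is compound 1, and the single step of a 2.9-fold higher number from compound 1 to compound 2 (0.46 log units; beyond the scatter) is beyond the scatter but modest. Compound 3 `CN(C)C1(COc2cnc(Cl)c(Br)c2)CC1` keeps the whole of compound 2 and differs only in this: chloro in place of hydrogen on an aromatic carbon. Going by the values given here, the one measured step that bears on this change is a 2.9-fold higher number from compound 1 to compound 2 (0.46 log units; beyond the scatter), where a group of the same kind entered the same ring; nothing measured reports what a second such entry does once bromo is already present. The expected outcome is therefore a small rise in the number, or none beyond the scatter, expressed as a 1.4-fold higher number from compound 2 to compound 3 (0.14 log units; within the scatter). For compound 3 the estimate in this assay is 380 nM, with a range from 130 nM to 1100 nM.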

Compound 3, inhibition constant: 110 nM
For compound 3 the middle estimate is 3.5-fold (0.54 log units) above the measured one, and the stated range ends above it.
By their numbers in this assay, from the lowest: compounds 1 and 3 (each within the scatter of the next); then compound 2.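

Chloro in place of hydrogen, next to the ring nitrogen and ortho to a bromo group, gives a 2.5-fold lower number from compound 2 to compound 3 (0.39 log units; beyond the scatter) in this assay. This runs in the opposite direction to the earlier bromo step, a 2.9-fold higher number from compound 1 to compound 2 (0.46 log units; beyond the scatter), so among these compounds a halogen entering this ring does not shift the number one fixed way. No supporting data are available to account for this difference in direction.

Open, as far as these compounds go, is whether the lower number is specific to chloro or would also follow from another group at this position, such as fluoro, methyl, methoxy or an amine. Also open, from the compounds shown here alone, is whether chloro at this position gives a step of similar size and direction on the core of compound 1, where no bromo group is present.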